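Compound 4: an acetyl swap at the assay's limit

The source may report more compounds than this note shows. Statements on the series, on what has been measured and on what is new or still open speak of the compounds shown alone.

Measured in an ADME assay on Vero cells (Chlorocebus sabaeus) for cytotoxicity, read by MTT assay, with a stated time of 96 h; on this read-out lower numbers stand for higher toxicity in this test and higher numbers for lower toxicity in this test:
Compound 1 `CC(=O)c1ccc2[nH]c(-c3ccccc3)nc2c1`: > 100000 nM
Compound 2 `COc1ccc(-c2nc3cc(/C(C)=N/NC(N)=S)ccc3[nH]2)cc1`: > 100000 nM
Compound 3 `CC(=O)c1ccc2[nH]c(-c3ccoc3)nc2c1`: > 100000 nM

Each of these three entries is a limit of the assay and not a number. Compound 3 stands at > 100000 nM, which is a limit. It shares that position with the other two compounds, as the limit of > 100000 nM in this assay, at which 3 of the 3 values shown sit, records.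

Compound 4 `C/C(=N\NC(N)=S)c1ccc2[nH]c(-c3ccoc3)nc2c1` differs from compound 3 in one group, on an aromatic carbon: a group of 7 heavy atoms (3 carbon, 3 nitrogen, 1 sulfur; no ring) in place of a group of 3 heavy atoms (2 carbon, 1 oxygen; no ring), on an aromatic carbon. The acetyl leaves, and a group with no common name enters.

For the measured compounds named here, the one measured step is a step that the two limits leave unreadable from compound 1 to compound 3. It concerns furan-3-yl in place of phenyl, not the group that changes here, so it gives no size to carry over. Compound 2 carries the same entering group on a different aryl substituent. Compound 2 sits at > 100000 nM, again a limit.

Going by the values given here, no step of readable size therefore bears on this change. In this assay none beyond the scatter is expected, though a drop towards higher toxicity in this test cannot be excluded. The estimated step is an at least 1.1-fold lower number from compound 3 to compound 4 (0.04 log units; that floor lies within the scatter). For compound 4 the expected value is 90000 nM, with an estimated range from 30000 nM to 150000 nM.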

Compound 4, half-maximal cytotoxic concentration: 100000 nM
The estimate for compound 4 lay 1.1-fold (0.05 log units) below the measured number; the range from low to high includes it.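

In this assay compound 4 gives 100000 nM, which is a number and not a limit, so a group with no common name in place of acetyl at this position yields the first readable value among the compounds shown. The steps to compound 4 from compound 3 and from compound 2 cannot be read, because the values they start from are limits of the assay: the limit of > 100000 nM in this assay, at which 3 of the 4 values shown sit. The result therefore shows only a number no higher from compound 3 to compound 4 (the limit leaves the size open) and a number no higher from compound 2 to compound 4 (the limit leaves the size open) as the two new steps.

The compounds shown leave open how far compound 3 and compound 2 actually lie from compound 4, and whether the entering group lowers the number at all. They also leave open what an amine or a carboxylic acid in place of acetyl at this position would give in this assay.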